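A few compounds are considered here, and "the series" means these few. Any claim that something is new, unique, unknown or untested is made for them only; others in the source may bear on it.

Working notes on the series. Compound 1 `Cc1cc(=O)n(-c2cccc(F)c2)nc1C(=O)Nc1ccc(Oc2ncnc3[nH]ccc23)c(F)c1` gives 23100 nM in a functional assay on HepG2 cells (Homo sapiens) for cytotoxicity, read by MTT assay, with a stated time of 72 h; a lower number here means a stronger inhibitor, a higher number a weaker inhibitor. Compound 2 `Cc1ccc(-n2nc(C(=O)Nc3ccc(Oc4ncnc5[nH]ccc45)c(F)c3)c(C)cc2=O)cc1` gives 18800 nM in this assay; the step of a 1.2-fold lower number from compound 1 to compound 2 (0.09 log units; within the scatter) rests on the change (4-methylphenyl in place of 3-fluorophenyl on an aromatic nitrogen). Compound 3 `Cc1cc(=O)n(-c2cccc(F)c2)nc1C(=O)Nc1ccc(Oc2ncnc3c2ccn3C)c(F)c1` differs from compound 1 in the core by methyl in place of hydrogen on an aromatic nitrogen. For compound 3 the result in this assay is a limit of the assay, > 60000 nM. This sits at the limit of > 60000 nM in this assay, at which 1 of the 3 values shown sits. The step of an at least 2.5-fold higher number from compound 1 to compound 3 (0.41 log units; beyond the scatter) is therefore read against that limit and not against a number.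

Compound 4 `Cc1ccc(-n2nc(C(=O)Nc3ccc(Oc4ncnc5c4ccn5C)c(F)c3)c(C)cc2=O)cc1` is not yet measured in this assay. For the measured compounds named here, it carries the change (4-methylphenyl in place of 3-fluorophenyl on an aromatic nitrogen), which is the same change, at the same place, as the one made from compound 1 to compound 2. That change has already been measured once, as a 1.2-fold lower number from compound 1 to compound 2 (0.09 log units; within the scatter). On that basis, for compound 4 the step that the limit leaves unreadable from compound 3 to compound 4 is expected to be small. For compound 4 the estimate in this assay is 80000 nM, between 40000 nM and 200000 nM, with a limit rather than a number the likelier outcome.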

Compound 4, half-maximal inhibitory concentration: > 60000 nM
Compound 4: no number, only a limit (the forecaster's own chance of this, stated with the estimate: 75%); the middle value lies beyond the limit too.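

Methyl in place of hydrogen on the aromatic nitrogen, now with 4-methylphenyl on the other aromatic nitrogen, gives an at least 3.1-fold higher number from compound 2 to compound 4 (0.50 log units; beyond the scatter) in this assay. On the two aryl groups shown, 3-fluorophenyl and 4-methylphenyl, this change therefore goes the same way and lies beyond the scatter, but the size of the step on each core remains unresolved, so this pair does not show that the step is equal or unequal: the same change on two cores in this assay, an at least 2.5-fold higher number (0.41 log units; beyond the scatter) from compound 1 to compound 3 and an at least 3.1-fold higher number (0.50 log units; beyond the scatter) from compound 2 to compound 4; the limit leaves it open whether they differ The exchange of 3-fluorophenyl for 4-methylphenyl cannot be read on the methylated core, where compound 3 and compound 4 both stand at a limit and not at a number: the limit of > 60000 nM in this assay, at which 2 of the 4 values shown sit.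

The compounds shown leave open how a longer chain in place of the methyl on that aromatic nitrogen would read in this assay. They also leave open whether an amine or a carboxylic acid on the phenyl ring would give a number within the range of the assay on the methylated core.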